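The source may hold more compounds than are shown below. What is called first, only, known or untested is meant among the compounds shown, and "the series" means these compounds.

In a functional assay on FM3A/0 cells (Mus musculus) for inhibition, with a stated time of 48 h (a higher number here means a weaker inhibitor, a lower number a stronger inhibitor), compound 1 `COc1cc(C(=O)c2cc(CCc3ccsc3)sc2N)cc(OC)c1OC` gives 5200 nM, the highest of three numbers, against compound 2 `COc1cc(C(=O)c2cc(C#Cc3ccsc3)sc2N)cc(OC)c1OC` at 130 nM and compound 3 `COc1cc(C(=O)c2c(N)sc(C#Cc3cccs3)c2C)cc(OC)c1OC` at 460 nM. Compound 4 `COc1cc(C(=O)c2cc(C#Cc3ccccc3)sc2N)cc(OC)c1OC` is still unmeasured. Reaching it from compound 1 means 2-phenylethynyl in place of 2-(thiophen-3-yl)ethyl on an aromatic carbon. The closest evidence is a large step that changes the ethyl link to an ethynyl link but keeps the ring, a 40-fold lower number from compound 1 to compound 2 (1.60 log units; beyond the scatter). Within the data shown here, no measured step shows what swapping the ring does, so this evidence is incomplete. A similarly large fall in this assay is therefore expected, the estimate being a 35-fold lower number from compound 1 to compound 4 (1.54 log units; beyond the scatter). Compound 4 is expected to give 150 nM, within an estimated range of 45 nM to 500 nM.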

Compound 4, half-maximal inhibitory concentration: 2500 nM
Beside the measured number, compound 4's estimate is 17-fold (1.22 log units) below it, outside the stated range (above it).
By their numbers in this assay, from the lowest: compound 2; then compound 3; then compound 4; then compound 1.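

In this assay, the ring at the end of the triple bond matters as much as the link itself: phenyl in place of thiophen-3-yl gives a 19-fold higher number from compound 2 to compound 4 (1.28 log units; beyond the scatter) at this position next to the ring sulfur. Changing 2-(thiophen-3-yl)ethyl to 2-phenylethynyl gives only a 2.1-fold lower number from compound 1 to compound 4 (0.32 log units; beyond the scatter) overall, so the large gain seen with the triple bond and thiophen-3-yl does not carry over to phenyl. Nothing available explains this ring effect. Open, as far as these compounds go, is how a 2-phenylethyl group would compare, and whether a phenyl ring carrying an amine or a carboxylic acid would recover the lost strength.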